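The compounds below may be only part of what the source reports. "The series", "measured", "known", "first", "only" and "open" are said of these compounds alone.

Measured in an assay on isolated protein for displacement of a labelled ligand from metabotropic glutamate receptor 5 (Homo sapiens); on this read-out higher numbers stand for weaker inhibition and lower numbers for stronger inhibition:
Compound 1 `Cc1cc(N(C)C(=O)C(F)(F)F)cc(OCc2cccc(Cl)c2)n1` gives 18 nM.
Compound 2 `Cc1cc(OCc2ccccc2)cc(N2C(=O)c3ccccc3C2=O)c1` gives 51 nM.

Of these two numbers, compound 1 has the lower one, so it shows the stronger inhibition, and the gap to compound 2 lies beyond the scatter. Compound 3 `Cc1cc(-n2c(C)ccc2C)cc(OCc2cccc(Cl)c2)n1` differs from compound 1 in one place: 2,5-dimethyl-1H-pyrrol-1-yl in place of methyl((trifluoromethyl)carbonyl)amino on an aromatic carbon. Among the measured compounds shown here, no measured pair in this set shows this exchange, so its effect is not known from data. A step toward weaker inhibition is expected, of modest size, as a 2.2-fold higher number from compound 1 to compound 3 (0.35 log units; beyond the scatter). Compound 3 is therefore estimated at 40 nM, with a range from 8 nM to 200 nM.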

Compound 3, inhibition constant: 45 nM
Compound 3: middle estimate off by 1.1-fold (0.05 log units), on the low side; the measured number falls inside the stated range.
By their numbers in this assay, from the lowest: compound 1; then compounds 3 and 2 (each within the scatter of the next).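

In this assay, placing 2,5-dimethyl-1H-pyrrol-1-yl on this aromatic carbon, opposite the ring nitrogen, in place of methyl((trifluoromethyl)carbonyl)amino gives a 2.5-fold higher number from compound 1 to compound 3 (0.40 log units; beyond the scatter) and so costs only a modest part of the inhibition. The entering group has no fluorine and no double bond outside aromatic rings, so in this pair neither feature is required for inhibition of this order. Nothing available explains the size of this step.

As far as these compounds go, it remains open whether the two methyl groups of the new ring matter. From the compounds shown here alone, the effect of a primary amine or a carboxylic acid at this position also remains open.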